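This account rests on a few compounds, and the source may have more. Where it says the series, first, only, none or still open, it means among the compounds named here.

Among the measured compounds shown here, compound 1 `O=C(NCCNS(=O)(=O)c1sccc1-c1ccccc1Oc1ccc(O)c(O)c1)Nc1cc(Cl)cc(Cl)c1` is the first of the set. In a functional assay on HeLa cells (Homo sapiens) for inhibition, read by CCK-8 assay, with a stated time of 48 h (a lower number here means a stronger inhibitor, a higher number a weaker inhibitor), compound 1 gives > 50000 nM, which is a limit of the assay and not a number. Compound 3 `CC(C)c1ccc(Oc2ccc(O)c(O)c2)c(-c2ccsc2S(=O)(=O)NCCNC(=O)Nc2cc(Cl)cc(Cl)c2)c1` differs from it by isopropyl in place of hydrogen on an aromatic carbon. In this assay compound 3 also gives > 50000 nM, again a limit rather than a number. The step that the two limits leave unreadable from compound 1 to compound 3 therefore cannot be read, since both ends sit at the limit of > 50000 nM in this assay, at which 2 of the 3 values shown sit.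

Compound 2 `COc1ccc(Oc2ccccc2-c2ccsc2S(=O)(=O)NCCNC(=S)Nc2cc(C(F)(F)F)cc(C(F)(F)F)c2)cc1OC` has a different core; the difference between the two cores is not broken down here. In this assay, for the measured compounds named here, compound 2 gives 6400 nM, the only number among the measured values. Compound 4 `COc1ccc(Oc2ccc(C(C)C)cc2-c2ccsc2S(=O)(=O)NCCNC(=S)Nc2cc(C(F)(F)F)cc(C(F)(F)F)c2)cc1OC`, not yet measured, differs from compound 2 by isopropyl in place of hydrogen on an aromatic carbon. This is the same kind of change as that from compound 1 to compound 3, but not the same: there the place is para to a 3,4-dihydroxyphenoxy group, here para to a 3,4-dimethoxyphenoxy group. Going by the values given here, with the only comparable step unreadable, the expected step of a 1.3-fold higher number from compound 2 to compound 4 (0.10 log units; within the scatter) is kept modest and uncertain. Compound 4 is estimated at 8000 nM, between 2500 nM and 30000 nM.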

Compound 4, half-maximal inhibitory concentration: 8300 nM
Compound 4: middle estimate off by 1.0-fold (0.02 log units), on the low side, and the stated range covers the measured number.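

In this assay, isopropyl in place of hydrogen on an aromatic carbon gives a 1.3-fold higher number from compound 2 to compound 4 (0.11 log units; within the scatter), so on the core of compound 2 the change leaves the two values within the usual scatter of each other. The same change on the core of compound 1 cannot be read, since both ends of that step are limits of the assay and not numbers: the limit of > 50000 nM in this assay, at which 2 of the 4 values shown sit.

This gives one readable case and no comparison between cores, so it does not show whether the change carries from one core to the other, and the result applies only to the place para to a 3,4-dimethoxyphenoxy group. The compounds shown leave open how a group other than isopropyl on that aromatic carbon, such as an amine, a carboxylic acid or a longer chain, would read in this assay. Also open, from the compounds shown here alone, is how such groups would read on the core of compound 1, where the values shown are limits.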